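The source may hold more compounds than are shown below. What is called first, only, known or untested is meant among the compounds shown, and "the series" means these compounds.

Measured so far in a functional assay on HOP-62 cells (Homo sapiens) for inhibition, read by sulforhodamine B assay, with a stated time of 48 h, tested at 100 uM; a lower number here means a stronger effect, a higher number a weaker effect of the compound at the concentration tested:
Compound 1 `O=C(Nc1cccc(-n2cc(-c3ccncc3)c(-c3cc(O)cc(Cl)c3)n2)c1)Nc1ccc(Cl)c(C(F)(F)F)c1` gives -12%.
Compound 2 `O=C(Nc1cccc(-n2cc(-c3ccncc3)c(-c3cc(O)cc(Cl)c3)n2)c1)Nc1ccc(Cl)c(Cl)c1` gives -3%.
Compound 3 `COc1cc(Cl)cc(-c2nn(-c3cccc(NC(=O)Nc4cc(C(F)(F)F)cc(C(F)(F)F)c4)c3)cc2-c2ccncc2)c1` gives -60%.

Compound 3 stands lowest of the three numbers; its nearest neighbour is compound 1, and both compound 1 and compound 2 lie beyond the scatter above it. Compound 4 `COc1cc(Cl)cc(-c2nn(-c3cccc(NC(=O)Nc4cccc(C(F)(F)F)c4)c3)cc2-c2ccncc2)c1` differs from compound 3 by hydrogen in place of trifluoromethyl on an aromatic carbon. Among the compounds with values here, the only measured step that touches a trifluoromethyl is a number 9 percentage points higher from compound 1 to compound 2 (within the scatter), which lay within the scatter, but there chloro entered, not hydrogen, and the two ureas carry different groups elsewhere, so no step bears directly on this change. The expectation is a modest move towards a higher number, with wide uncertainty, as a number 25 percentage points higher from compound 3 to compound 4 (beyond the scatter). Compound 4 is therefore estimated at -35%, in the range -65% to -5%.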

Compound 4, a percentage reported as activity, at one concentration (the size of the read-out at that concentration, not a potency): -41%
Compound 4: the middle estimate sits 6 percentage points above what was measured; measured number inside the range.
By their numbers in this assay, from the lowest: compound 3; then compound 4; then compounds 1 and 2 (each within the scatter of the next).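

In this assay, hydrogen entering in place of one trifluoromethyl, meta to the remaining trifluoromethyl group, gives a number 19 percentage points higher from compound 3 to compound 4 (beyond the scatter), a modest step. Within the data shown here, the only earlier step, chloro in place of trifluoromethyl in another pair of ureas, stayed within the scatter, whereas this change at this position does move the number. No measurement at hand accounts for the step.

Open, on these data alone, is where a methyl, a methoxy or a carboxylic acid at this position would fall relative to compound 3 and compound 4. Also open, as far as these compounds go, is whether the same hydrogen change would move the number on the hydroxy-bearing compounds.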